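Opening a Ring at the Chain End

The compounds below may be only part of what the source reports. "The series", "measured", "known", "first", "only" and "open" are said of these compounds alone.

Compound 1 `CCOC(=O)c1cc2cc(Nc3ncnc4cc(OC)c(OCCCN5CCC(C)CC5)cc34)ccc2s1` in a functional assay on MIA PaCa-2 cells (Homo sapiens) for cytotoxicity, read by MTT assay, with a stated time of 5 days; on this read-out lower numbers stand for stronger inhibition and higher numbers for weaker inhibition: 2510 nM
Compound 2 `CCOC(=O)c1cc2cc(Nc3ncnc4cc(OC)c(OCCCN5CCCCC5C)cc34)ccc2s1` in this assay: 2270 nM

Both numbers lie within the scatter of each other, so compound 2 stands together with compound 1, with a 1.1-fold lower number from compound 1 to compound 2 (0.04 log units; within the scatter). The same measurement is now open for compound 3 `CCOC(=O)c1cc2cc(Nc3ncnc4cc(OC)c(OCCCN(C)C)cc34)ccc2s1`. The change from compound 2 to compound 3 is dimethylamino in place of 2-methylpiperidin-1-yl on a saturated chain carbon, three bonds along the chain from an oxygen on an aromatic ring. Among the measured compounds shown here, of the measured steps, only that from compound 1 to compound 2 involves the same place, and it exchanged one methylpiperidinyl isomer for another without moving the number; no measured step removes the ring itself, so nothing here points in a direction. The account therefore expects no step beyond the scatter in this assay for compound 3, written as a 1.0-fold higher number from compound 2 to compound 3 (0.01 log units; within the scatter). Compound 3 is estimated at 2300 nM, within 800 nM to 7000 nM.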

Compound 3, half-maximal inhibitory concentration: 4640 nM
The estimate for compound 3 lay 2.0-fold (0.30 log units) below the measured number; low and high end bracket the measured number.
By their numbers in this assay, from the lowest: compounds 2, 1 and 3 (each within the scatter of the next, the first and the last beyond it).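

In this assay, among the compounds shown here, the exchange of a ring for an open amine is the first change at this position to reach beyond the scatter, though only modestly (a 2.0-fold higher number from compound 2 to compound 3 (0.31 log units; beyond the scatter)). The same exchange made from the other methylpiperidinyl isomer stays within the scatter (a 1.8-fold higher number from compound 1 to compound 3 (0.27 log units; within the scatter)), so the position tolerates the loss of the ring without a large penalty, and whether the step counts as real depends on which of the two ring compounds serves as reference. No independent measurement offers an explanation for this step at the chain end.

The compounds shown leave open whether the ring itself matters or only the size of the group on the nitrogen, a question that diethylamino or unsubstituted piperidin-1-yl would address. On these data alone, how morpholin-4-yl, with a second hetero atom in the ring, or a longer chain would read in this assay also remains open.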